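Extending the amine chain in a cytotoxicity series

The source may report more compounds than this note shows. Statements on the series, on what has been measured and on what is new or still open speak of the compounds shown alone.

In a functional assay on HT-29 cells (Homo sapiens) for cytotoxicity, read by neutral red uptake, with a stated time of 72 h (a lower number here means a stronger inhibitor, a higher number a weaker inhibitor), three compounds have been measured. Compound 1 `CCCNc1nc(NCCC)c2ccccc2n1` gives 18900 nM. Compound 2 `Cc1ccc(CNc2nc(NCc3ccc(C)cc3)c3ccccc3n2)cc1` gives 4420 nM. Compound 3 `CCNc1nc(SCC)nc2ncccc12` gives 26200 nM, the highest of the three numbers; compound 1 stands within the scatter of it, while compound 2 gives a number well below it, beyond the scatter. Within the data shown here, compound 2 carries larger groups on both amine nitrogens than compound 1, and the two values show a lower number for compound 2 than for compound 1, though no single-point step connects them.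

The step to compound 4 `CCCCCNc1nc(SCC)nc2ncccc12` is propyl in place of hydrogen on a saturated chain carbon, two bonds along the chain from a nitrogen on an aromatic ring, turning the ethylamino group of compound 3 into a pentylamino group. Among the measured compounds the only hint is the comparison of compound 1 with compound 2, which show a lower number for the larger substituents on the amine nitrogens. On that slim basis a modest decrease in the number from compound 3 to compound 4 is expected, of a size near the edge of the scatter rather than clearly beyond it, giving an expected 2.0-fold lower number from compound 3 to compound 4 (0.30 log units; within the scatter). Compound 4 is therefore estimated to give 13000 nM in this assay, with a range from 4500 nM to 38000 nM.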

Compound 4, half-maximal inhibitory concentration: 5100 nM
For compound 4 the middle estimate is 2.5-fold (0.41 log units) above the measured one, and the stated range covers the measured number.
By their numbers in this assay, from the lowest: compounds 2 and 4 (each within the scatter of the next); then compounds 1 and 3 (each within the scatter of the next).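

Lengthening the ethylamino group of compound 3 to the pentylamino group of compound 4 gives a 5.1-fold lower number from compound 3 to compound 4 (0.71 log units; beyond the scatter) in this assay, and this is the first step in the set that differs in one place only. Among these compounds, it shows that propyl in place of hydrogen on this saturated chain carbon, two bonds along the chain from a nitrogen on an aromatic ring, moves the number beyond the scatter, whereas the earlier hint about larger amine groups rested on compounds with no single-place step between them. Nothing available accounts for why the longer chain goes with the lower number.

On these data alone, with only the ethylamino and pentylamino groups to compare at this place, it remains open whether a longer chain such as octyl would lower the number further or whether the change would level off. As far as these compounds go, it is also open whether a chain ending in an amine or a carboxylic acid would keep the lower number, and whether the same lengthening would give a step of similar size on a different core.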